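Swapping Nitrophenyl for Dihydroxyphenyl on the Imine Carbon

A few compounds are considered here, and "the series" means these few. Any claim that something is new, unique, unknown or untested is made for them only; others in the source may bear on it.

Compound 1 `CCCCc1oc2ccc(/N=C/c3ccc(O)cc3)cc2c1C(=O)c1ccc(OC)cc1`: 22.8 ug/mL
Compound 2 `CCCCc1oc2ccc(/N=C/c3ccc([N+](=O)[O-])cc3)cc2c1C(=O)c1ccc(OC)cc1`: 53.1 ug/mL

In a functional assay, with a stated time of 30 min (on this read-out higher numbers stand for weaker inhibition and lower numbers for stronger inhibition), compound 2 stands highest of the two numbers, and compound 1 sits the nearest to it. Compound 3 `CCCCc1oc2ccc(/N=C/c3ccc(O)cc3O)cc2c1C(=O)c1ccc(OC)cc1` differs from compound 2 by 2,4-dihydroxyphenyl in place of 4-nitrophenyl on a carbon with a double bond to nitrogen. Among the compounds with values here, one measured step bears on this change: a 2.3-fold higher number from compound 1 to compound 2 (0.37 log units; beyond the scatter), in which hydroxy gave way to nitro. The change to compound 3 brings the hydroxy back and adds a second one. Given the step of a 2.3-fold higher number from compound 1 to compound 2 (0.37 log units; beyond the scatter), a lower number is expected, around a 2.4-fold lower number from compound 2 to compound 3 (0.38 log units; beyond the scatter). Compound 3 is estimated at 22 ug/mL, with a range from 9 ug/mL to 50 ug/mL.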

Compound 3, half-maximal inhibitory concentration: 7.55 ug/mL
Compound 3: the middle estimate sits 2.9-fold (0.46 log units) above what was measured, outside the stated range (below it).
By their numbers in this assay, from the lowest: compound 3; then compound 1; then compound 2.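

On the carbon with a double bond to nitrogen, 2,4-dihydroxyphenyl in place of 4-nitrophenyl gives a 7.0-fold lower number from compound 2 to compound 3 (0.85 log units; beyond the scatter) in this assay, more than the return of a single hydroxy had suggested. The added hydroxy counts by itself, with a 3.0-fold lower number from compound 1 to compound 3 (0.48 log units; beyond the scatter) for hydroxy in place of hydrogen on an aromatic carbon. Nothing measured here explains this gain.

As far as these compounds go, whether the added group must be a hydroxy stays open, since a methoxy or an amine in its place could give a different number. From the compounds shown here alone, how either compares with a carboxylic acid on that ring also remains unknown.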